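A few compounds are considered here, and "the series" means these few. Any claim that something is new, unique, unknown or untested is made for them only; others in the source may bear on it.

The measured compounds, with their values in an assay on CHO cells for agonist activity at Free fatty acid receptor 1 (Homo sapiens), read by FLIPR; a lower number here means that less compound is needed, a higher number that more compound is needed for the effect:

compound 1, `Cc1nc(-c2ccccc2)sc1COc1ccc(OCC(=O)O)c(F)c1`: 374 nM
compound 2, `Cc1nc(-c2ccc(C(F)(F)F)cc2)sc1COc1ccc(OCC(=O)O)c(F)c1`: 149 nM
compound 3, `Cc1nc(-c2ccc(F)cc2)sc1COc1ccc(OCC(=O)O)c(F)c1`: 112 nM

Compound 3 gives the lowest of the three numbers in this assay, but its gap to compound 2, a 1.3-fold lower number from compound 2 to compound 3 (0.12 log units; within the scatter), lies within the scatter; only compound 1 stands clearly apart from it. Compound 4, `Cc1nc(-c2cccc(F)c2)sc1COc1ccc(OCC(=O)O)c(F)c1`, is the next compound to be measured. Its change from compound 3 is 3-fluorophenyl in place of 4-fluorophenyl on an aromatic carbon. Among the compounds with values here, none of the measured steps moves a substituent from one carbon of this phenyl ring to another, so no step matches the change directly. Within the data shown here, the steps that bear on it are those that put a group onto that phenyl ring at all: a 3.3-fold lower number from compound 1 to compound 3 (0.52 log units; beyond the scatter) and a 2.5-fold lower number from compound 1 to compound 2 (0.40 log units; beyond the scatter), both modest and both beyond the scatter, which show that the unsubstituted ring of compound 1 gives the highest number of the three. On these data alone, whether the fluorine does the same work from its new place is unknown. The step expected is therefore small, a 1.4-fold higher number from compound 3 to compound 4 (0.15 log units; within the scatter), with wide uncertainty. Compound 4 is estimated at 160 nM in this assay, between 60 nM and 420 nM.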

Compound 4, half-maximal effective concentration: 185 nM
The estimate for compound 4 lay 1.2-fold (0.06 log units) below the measured number; measured number inside the range.
By their numbers in this assay, from the lowest: compounds 3, 2 and 4 (each within the scatter of the next); then compound 1.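

In this assay, the place of the fluorine on this phenyl ring cannot be shown to matter: a 1.7-fold higher number from compound 3 to compound 4 (0.22 log units; within the scatter) is a step that stays within the scatter, so 3-fluorophenyl and 4-fluorophenyl cannot be told apart at this position. The separation from the unsubstituted phenyl ring is therefore not confined to 4-fluorophenyl, since a 2.0-fold lower number from compound 1 to compound 4 (0.31 log units; beyond the scatter) still lies beyond the scatter, while a 1.2-fold higher number from compound 2 to compound 4 (0.09 log units; within the scatter) leaves 3-fluorophenyl and 4-(trifluoromethyl)phenyl inseparable as well. Nothing available gives a reason for these steps.

On these data alone, whether a chloro, methoxy or nitrile group on this phenyl ring would match fluoro remains open, as does whether a ring carrying two fluorines would stand clearly apart from compound 3 and compound 4. Also open, as far as these compounds go, is whether trifluoromethyl, seen here only as 4-(trifluoromethyl)phenyl, would be as insensitive to a shift around the ring as fluoro appears to be.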